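Ester for acid on a fused seven-membered aromatic core

The source may hold more compounds than are shown below. What is called first, only, known or untested is meant among the compounds shown, and "the series" means these compounds.

Going by the values given here, only two compounds have been measured, and their numbers sit close together. In an assay on cells for displacement of a labelled ligand from Orexin receptor type 2 (Homo sapiens), read by scintillation counting, with stated times of 10 min and 90 min, tested at 10 uM (a lower number here means less inhibition, a higher number more inhibition at the concentration tested (going by the name of the read-out)), compound 1 `O=C(O)c1ccc2ccc(C(=O)c3ccccc3)c-2cc1` gives 32.9%, while compound 2 `O=C(O)c1ccc2c(C(=O)c3ccccc3)cc(C(=O)c3ccccc3)c-2cc1` gives 27%. Among the compounds with values here, the one measured step, a number 5.9 percentage points lower from compound 1 to compound 2 (within the scatter), is within the scatter, so neither compound can be set above the other on this evidence.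

Compound 3 `COC(=O)Cc1ccc2ccc(C(=O)c3ccccc3)c-2cc1` differs from compound 1 in a single place: (methoxycarbonyl)methyl in place of carboxy on an aromatic carbon. Within the data shown here, the measured step from compound 1 to compound 2 concerns a benzoyl group and a different aromatic carbon; it says nothing about swapping an acid for an ester, so no measured step bears on this change. With nothing to lean on, the expected step of a number 2.9 percentage points lower from compound 1 to compound 3 (within the scatter) is taken as none beyond the scatter, with a wide range to reflect the uncertainty. Compound 3 is therefore estimated at 30% in this assay, expected to fall between 5% and 55%.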

Compound 3, a percentage reported as inhibition, at one concentration (the size of the read-out at that concentration, not a potency): -4.3%
Compound 3: the middle estimate sits 34.3 percentage points above what was measured; measured number below the stated range.
By their numbers in this assay, from the lowest: compound 3; then compounds 2 and 1 (each within the scatter of the next).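

This aromatic carbon of the seven-membered ring is sensitive to what it carries: in this assay, replacing carboxy with (methoxycarbonyl)methyl gives a number 37.2 percentage points lower from compound 1 to compound 3 (beyond the scatter). The earlier benzoyl step, made at a different aromatic carbon, stayed within the scatter, so this is the first change shown to move the number clearly, and compound 3 at -4.3% shows no measurable inhibition at the concentration tested. Nothing available explains this drop.

The swap changes several things at once: it removes the acid, adds a carbon chain link and leaves the ester's methyl on the end, so the compounds shown cannot say which of these matters. A carboxymethyl group, which keeps the acid on the longer chain, or a methyl ester set directly on the aromatic carbon, would pull these apart.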